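Swapping chloro for bromo on a naphthalene-bearing cytotoxicity series

A few compounds are considered here, and "the series" means these few. Any claim that something is new, unique, unknown or untested is made for them only; others in the source may bear on it.

Among the compounds with values here, compound 1 `N#Cc1ccc(Nc2nccc(Oc3ccc4cc(C#N)ccc4c3Cl)n2)cc1` is the one member of this small set with a definite number: in an ADME assay on MT4 cells (Homo sapiens) for cytotoxicity, read by MTT assay, with a stated time of 4 days (on this read-out higher numbers stand for lower toxicity in this test and lower numbers for higher toxicity in this test), compound 1 gives 269000 nM. Compound 2 `COc1cc2cc(C#N)ccc2c(Cl)c1Oc1ccnc(Nc2ccc(C#N)cc2)n1` reaches only a limit of the assay, and in this assay compound 2 gives > 190000 nM. Compound 3 `Cc1cc(Oc2ccc3cc(C#N)ccc3c2)nc(Nc2ccc(C#N)cc2)n1` likewise reaches only a limit, and in this assay compound 3 gives > 331000 nM. Within the data shown here, the single comparable step, from compound 1 to compound 2 in this assay, is a step that the limit leaves unreadable from compound 1 to compound 2, which cannot be sized because of the limit of > 190000 nM in this assay, at which 1 of the 3 values shown sits. Among the measured compounds shown here, no measured step touches a halogen exchange.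

Compound 4 `N#Cc1ccc(Nc2nccc(Oc3ccc4cc(C#N)ccc4c3Br)n2)cc1` differs from compound 1 by bromo in place of chloro on an aromatic carbon. For the measured compounds named here, with no measured step bearing on this change, no shift beyond the usual scatter is expected in this assay, and the step from compound 1 to compound 4 is estimated as no change at the digits printed from compound 1 to compound 4 (within the scatter). For compound 4 the expected value in this assay is therefore 269000 nM, with a range from 130000 nM to 550000 nM.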

Compound 4, half-maximal cytotoxic concentration: 283000 nM
Estimate against measurement, compound 4: 1.1-fold (0.02 log units) below, within the range that was stated.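

Within the data shown here, compound 4 supplies the first step in this set that can be read in this assay, and it is a 1.1-fold higher number from compound 1 to compound 4 (0.02 log units; within the scatter). On an aromatic carbon ortho to a fused ring and ortho to a large group, the two halogens therefore cannot be told apart on this read-out, with one heavy atom exchanged for another and no ring, hydrogen-bond donor, hydrogen-bond acceptor or net charge entering. Nothing shown gives a cause for this result.

As far as these compounds go, whether an amine or a carboxylic acid on that same aromatic carbon would also stay within the scatter of chloro remains open in this assay. The methoxy step to compound 2 still cannot be read, because compound 2 stands at a limit of the assay: the limit of > 190000 nM in this assay, at which 1 of the 4 values shown sits.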